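The source may report more compounds than this note shows. Statements on the series, on what has been measured and on what is new or still open speak of the compounds shown alone.

Measured so far in a functional assay on SW480 cells (Homo sapiens) for cytotoxicity, read by MTT assay, with a stated time of 48 h; on this read-out lower numbers stand for stronger inhibition and higher numbers for weaker inhibition:

- compound 1, `C=CC(=C)[C@@H](O)C[C@H]1C(=C)CC[C@@H]2[C@]1(C)CCC[C@]2(C)C(=O)O`: > 40000 nM, a limit of the assay
- compound 2, `C=C/C(C)=C/C[C@H]1C(=C)CC[C@@H]2[C@]1(C)CCC[C@]2(C)C=O`: > 40000 nM, a limit of the assay
- compound 3, `C=C1CC[C@@H]2[C@](C)(CCC[C@@]2(C)C(=O)O)[C@H]1CC/C(C)=C/COC(C)=O`: > 40000 nM, a limit of the assay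

Compound 1 stands nowhere distinct on the numbers shown: its value is only a limit, and the same is true of compound 2 and of compound 3. the limit of > 40000 nM in this assay, at which 3 of the 3 values shown sit, is the whole of the evidence in this assay. Within the data shown here, no pair of measured compounds differs in one place, so no measured step is available for comparison.

Compound 4, `C=C[C@]1(C)O[C@H]1C[C@H]1C(=C)CC[C@@H]2[C@]1(C)CCC[C@]2(C)C(=O)O`, has the same atoms as compound 1 joined differently: a group of 6 heavy atoms (5 carbon, 1 oxygen; one three-membered non-aromatic ring with 1 hetero atom) in place of a group of 6 heavy atoms (5 carbon, 1 oxygen; no ring), on a saturated chain carbon bound to a saturated ring carbon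

With every shown value sitting at the limit, the step from compound 1 to compound 4 in this assay is expected to be none beyond the scatter, the estimated step being a number no higher from compound 1 to compound 4 (the limit leaves the size open). Compound 4 is expected to give about 40000 nM in this assay, within 15000 nM to 100000 nM, most likely reported again only as a limit.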

Compound 4, half-maximal inhibitory concentration: > 40000 nM
Compound 4 ended at the assay's limit (the forecaster's own chance of this, stated with the estimate: 70%); the middle value sits exactly at the limit.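

Compound 1 and compound 4 both give only a limit in this assay, so no step can be read between them: the limit of > 40000 nM in this assay, at which 4 of the 4 values shown sit.

The compounds shown leave open whether the exchanged group has any effect on this read-out, since none gives a value inside the assay's range.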